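This account rests on a few compounds, and the source may have more. Where it says the series, first, only, none or still open, it means among the compounds named here.

In a functional assay on the whole organism for inhibition, with Rattus norvegicus as the target, at a dose of 30 mg/kg (on this read-out lower numbers stand for less inhibition and higher numbers for more inhibition at the one dose given (going by the name of the read-out)), three compounds have been measured. Compound 1 `CCOCCC/N=C(\S)n1ncnc1N` gives 1%, and compound 2 `CNC(=S)n1ncnc1NC` gives -1%. Compound 3 `CCOC(=O)C(=O)Nc1ccc(-c2nc(N)n(/C(S)=N/C)n2)cc1` gives 49%, the highest of the three numbers; the nearest to it is compound 1, lower by a gap beyond the scatter, and the furthest is compound 2, also lower by a gap beyond the scatter. Compound 4 `C/N=C(\S)n1nc(-c2ccc(C(F)(F)F)cc2)nc1N` has not been measured. It differs from compound 3 in one place: trifluoromethyl in place of ((ethoxycarbonyl)carbonyl)amino on an aromatic carbon. For the measured compounds named here, no pair of measured compounds differing in a single place is available, so the expectation rests on compound 3 alone. Compound 4 is expected to sit lower, with an estimated step of a number 24 percentage points lower from compound 3 to compound 4 (beyond the scatter), downward and beyond the scatter. Compound 4 is estimated at 25%, between 0% and 55%.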

Compound 4, a percentage reported as inhibition, in the whole organism at one dose (the size of the read-out at that dose, not a potency): 91%
Beside the measured number, compound 4's estimate is 66 percentage points below it, and the stated range ends below it.
By their numbers in this assay, from the lowest: compounds 2 and 1 (each within the scatter of the next); then compound 3; then compound 4.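

In this assay, the aromatic carbon on the six-membered ring proves sensitive to its substituent: trifluoromethyl in place of ((ethoxycarbonyl)carbonyl)amino gives a number 42 percentage points higher from compound 3 to compound 4 (beyond the scatter). The ((ethoxycarbonyl)carbonyl)amino group, with its hydrogen-bond donor and acceptors, is therefore not required for a high number at this position. No measurement available here accounts for the gain. As far as these compounds go, how an amine, a carboxylic acid or a chlorine atom would read at this aromatic carbon remains open. From the compounds shown here alone, it is also open whether the donor, the acceptors or the size of the departing group matters.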